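The source may report more compounds than this note shows. Statements on the series, on what has been measured and on what is new or still open speak of the compounds shown alone.

Series values in a functional assay on DU-145 cells (Homo sapiens) for antiproliferative activity, read by sulforhodamine B assay, with a stated time of 48 h; on this read-out lower numbers stand for stronger inhibition and higher numbers for weaker inhibition:
- Compound 1 `COc1ccc(-c2oc3c(OC)c(OC)cc(OCCCC(=O)NCc4ccccn4)c3c(=O)c2O)cc1`: > 40000 nM
- Compound 2 `CCCCN(C)C(=O)CCCCOc1cc(OC)c(OC)c2oc(-c3ccc(OC)cc3)c(O)c(=O)c12`: 10800 nM
- Compound 3 `COc1ccc(-c2oc3c(OC)c(OC)cc(OCCCCC(=O)NCc4ccccn4)c3c(=O)c2O)cc1`: not yet measured

The value of compound 1 is a limit: > 40000 nM. Going by the values given here, compound 2, at 10800 nM, holds the only actual number so far.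

The next change is ((pyridin-2-yl)methyl)amino in place of butyl(methyl)amino on a carbonyl carbon. Among the compounds with values here, one measured step bears on it, an at least 3.7-fold lower number from compound 1 to compound 2 (0.56 log units; beyond the scatter), which removes the group that compound 3 brings back. That step also differs in the chain, so only partial reversal is expected in this assay, towards a higher number. The expected change is a 2.0-fold higher number from compound 2 to compound 3 (0.31 log units; beyond the scatter). For compound 3 the estimate is 22000 nM, with an expected range of 10000 nM to 40000 nM.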

Compound 3, half-maximal inhibitory concentration: > 40000 nM
Compound 3: only a limit was reported; the forecaster's own chance of this, stated with the estimate: 35%; middle value at least 1.8-fold (0.25 log units) away from the limit.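

In this assay, with the chain held constant, ((pyridin-2-yl)methyl)amino in place of butyl(methyl)amino on the carbonyl carbon gives an at least 3.7-fold higher number from compound 2 to compound 3 (0.56 log units; beyond the scatter), isolating the amide change that the earlier step mixed with a chain change. Compound 1 and compound 3 are both limits, so the step between them cannot be read. Neither chain gives an actual number with the ((pyridin-2-yl)methyl)amino amide: the limit of > 40000 nM in this assay, at which 2 of the 3 values shown sit.

As far as these compounds go, it remains open whether the weaker result follows the pyridine ring or the amide hydrogen. A benzylamino or N-methyl-N-((pyridin-2-yl)methyl)amino amide on this carbonyl carbon would separate the two.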